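A 4-nitrobenzyl group replaces 2-fluorobenzyl on compound 3

This account rests on a few compounds, and the source may have more. Where it says the series, first, only, none or still open, it means among the compounds named here.

Measured so far in an ADME assay on J774.A1 cells (Mus musculus) for cytotoxicity, read by MTT assay, with a stated time of 48 h; on this read-out higher numbers stand for lower toxicity in this test and lower numbers for higher toxicity in this test:
- compound 1 `Cc1nc2ccccc2c(-c2ccccc2)c1C(=O)OCc1cn(Cc2ccc([N+](=O)[O-])cc2)nn1` gives 42000 nM
- compound 2 `Cc1nc2ccc(Cl)cc2c(-c2ccccc2)c1C(=O)OCc1cn(-c2ccc(C(C)C)cc2)nn1` gives "not determined" (no result reported)
- compound 3 `Cc1nc2ccc(Cl)cc2c(-c2ccccc2)c1C(=O)OCc1cn(Cc2ccccc2F)nn1` gives "not determined" (no result reported)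

In this assay compound 3 has no single number to stand on, and compound 2 is in the same position. The step to compound 4 `Cc1nc2ccc(Cl)cc2c(-c2ccccc2)c1C(=O)OCc1cn(Cc2ccc([N+](=O)[O-])cc2)nn1` is one structural change, (4-nitrophenyl in place of 2-fluorophenyl on a saturated chain carbon bound to an aromatic nitrogen), with 4-nitrophenyl in place of 2-fluorophenyl on a saturated chain carbon bound to an aromatic nitrogen. Cut one bond further out, this reads 2-fluorobenzyl to 4-nitrobenzyl. Among the compounds with values here, no step between measured compounds is available, so the size of this change cannot be read from the data. Within the data shown here, the only number belongs to compound 1 (42000 nM), which carries the same 4-nitrobenzyl group as compound 4. Relative to that number, no shift beyond the usual scatter is expected in this assay in either direction. Compound 4 is expected at 35000 nM within an estimated range from 12000 nM to 100000 nM on this read-out.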

Compound 4, half-maximal cytotoxic concentration: 75000 nM
Compound 4: the middle estimate sits 2.1-fold (0.33 log units) below what was measured; the measured number falls inside the stated range.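

In this assay, within the data shown here, chloro in place of hydrogen on an aromatic carbon gives a 1.8-fold higher number from compound 1 to compound 4 (0.25 log units; within the scatter), the first step in this set that can be read, and the 4-nitrobenzyl group stays the same across it. This shows that, with 4-nitrobenzyl in place, the shared core tolerates the chloro group without a shift beyond the scatter, while the steps that reach compound 2 or compound 3 cannot be read, and that includes the change from 2-fluorobenzyl to 4-nitrobenzyl. No measured evidence bears on this result.

Among the compounds shown, 4-nitrobenzyl is the only group on the saturated chain carbon bound to an aromatic nitrogen that carries a number, so the influence of that position remains open. Going by these compounds, how a benzyl group bearing an amine or a carboxylic acid, or a longer chain there, would read in this assay also remains open.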